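A Longer Chain and a Changed Linker on a Shared Core

The compounds below may be only part of what the source reports. "The series", "measured", "known", "first", "only" and "open" are said of these compounds alone.

Measured compounds:
compound 1, `CN(C)C(=O)c1cc2cnc(Nc3ccc(S(=O)(=O)NCCCCN=C=S)cc3)nc2n1C1CCCC1`: 39.4%
compound 2, `CN(C)C(=O)c1cc2cnc(Nc3ccc(S(=O)(=O)NCCCCCCN=C=S)cc3)nc2n1C1CCCC1`: 49.5%
compound 3, `CN(C)C(=O)c1cc2cnc(Nc3ccc(C(=O)NCCCN=C=S)cc3)nc2n1C1CCCC1`: 32.9%

Three analogues on the same core have been tested in a functional assay on A549 cells (Homo sapiens) for inhibition, read by CCK-8 assay, with a stated time of 72 h, tested at 1 uM; a higher number here means a stronger effect of the compound at the concentration tested, a lower number a weaker effect. Compound 1 sits second highest of the three numbers. Its nearest neighbour is compound 3, whose value lies within the scatter of it: a number 6.5 percentage points lower from compound 1 to compound 3 (within the scatter). Its furthest is compound 2, which lies beyond the scatter: a number 10.1 percentage points higher from compound 1 to compound 2 (beyond the scatter).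

The unmeasured compound 4, `CN(C)C(=O)c1cc2cnc(Nc3ccc(C(=O)NCCCCCN=C=S)cc3)nc2n1C1CCCC1`, differs from compound 1 in one place: a group of 11 heavy atoms (7 carbon, 2 nitrogen, 1 oxygen, 1 sulfur; no ring) in place of a group of 11 heavy atoms (5 carbon, 2 nitrogen, 2 oxygen, 2 sulfur; no ring), on an aromatic carbon. The entering group carries two more carbons than the one it replaces, while the oxygen and sulfur count falls.

Going by the values given here, two measured steps bear on this. Lengthening the chain by two carbons raised the read-out beyond the scatter in a number 10.1 percentage points higher from compound 1 to compound 2 (beyond the scatter), whereas changing the attachment at the aromatic carbon together with a shorter chain moved it only within the scatter in a number 6.5 percentage points lower from compound 1 to compound 3 (within the scatter). Compound 4 combines a changed attachment with a chain longer than that of compound 1, so a small rise is expected, though it may not clear the scatter.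

Compound 4 is therefore estimated at 43%, with a range from 31% to 55%, which means an expected step of a number 3.6 percentage points higher from compound 1 to compound 4 (within the scatter).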

Compound 4, a percentage reported as inhibition, at one concentration (the size of the read-out at that concentration, not a potency): 29.3%
Estimate against measurement, compound 4: 13.7 percentage points above; measured number below the stated range.
By their numbers in this assay, from the lowest: compounds 4, 3 and 1 (each within the scatter of the next, the first and the last beyond it); then compound 2.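

In this assay, lengthening the chain on the amide-linked compounds gives a number 3.6 percentage points lower from compound 3 to compound 4 (within the scatter), so the rise seen with the sulfonamide-linked pair does not recur here. Exchanging the whole group on the aromatic carbon, para to a large group, now gives a step that clears the scatter, a number 10.1 percentage points lower from compound 1 to compound 4 (beyond the scatter), although the entering group carries more carbon and the chain is not the shorter one. That exchange alters the link to the ring and the chain together, so the step cannot be credited to either alone, and the two chain steps do not establish that lengthening acts differently on the two cores: the same change on two cores in this assay, a number 10.1 percentage points higher (beyond the scatter) from compound 1 to compound 2 and a number 3.6 percentage points lower (within the scatter) from compound 3 to compound 4, 13.7 percentage points apart, within the scatter of two such steps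

The compounds shown leave open whether a sulfonamide and an amide with chains of identical length would differ, since no such matched pair appears among them. Also open, on these data alone, is how a longer chain on the amide-linked compounds, or an amine in place of the isothiocyanate at the chain end, would behave in this assay.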